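This account rests on a few compounds, and the source may have more. Where it says the series, first, only, none or still open, it means among the compounds named here.

Compound 1 `CNC(=O)c1cc(C(=O)N[C@H]2[C@@H]3C[C@H](O)C[C@@H]32)n([C@@H](C)c2cccc(Cl)c2)n1`: in a physicochemical assay for solubility, measured as kinetic solubility (a lower number here means a less soluble compound, a higher number a more soluble compound), compound 1 gives >= 168 ug/mL, which is a limit of the assay rather than a number.
Compound 2 `CNC(=O)c1cc(C(=O)N[C@H]2CC[C@H](O)CC2)n([C@@H](C)c2ccc(Cl)cc2)n1`: in this assay compound 2 gives >= 132 ug/mL, also a limit.
Compound 3 `CNC(=O)c1cc(C(=O)N[C@H]2CC[C@H](O)CC2)c([C@@H](C)c2ccc(Cl)cc2)o1`: in this assay compound 3 gives >= 118 ug/mL, again a limit.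

For compound 3 only a limit is known, as for the other two compounds, so no order among the three can be read from these values. Compound 4 `CNC(=O)c1cc(C(=O)N[C@H]2CC[C@H](O)CC2)c([C@@H](C)c2cccc(F)c2)o1` differs from compound 3 in a single place: 3-fluorophenyl in place of 4-chlorophenyl on a saturated chain carbon bound to an aromatic carbon and a saturated chain carbon. Going by the values given here, no measured pair of compounds differs in just this way, so the size of this step has not been seen. The expectation for this assay is a change no larger than the usual scatter, if anything toward a higher number. Compound 4 is therefore estimated to give about 150 ug/mL, within the range 80 ug/mL to 300 ug/mL, an expected step that the limit leaves unreadable from compound 3 to compound 4.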

Compound 4, solubility: >= 63 ug/mL
Compound 4 ended at the assay's limit; the forecaster's own chance of this, stated with the estimate: 65%; the middle value lies beyond the limit too.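

Going by these compounds alone, compound 3 and compound 4 both gave only limits of this assay, not numbers, so no step between them can be read. The compounds shown leave open whether 3-fluorophenyl in place of 4-chlorophenyl changes the read-out at all.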